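The source may report more compounds than this note shows. Statements on the series, on what has been measured and on what is new or still open speak of the compounds shown alone.

In a functional assay on HepG2 cells (Homo sapiens) for antiproliferative activity, read by MTT assay, with a stated time of 48 h (a lower number here means a stronger inhibitor of growth, a higher number a weaker inhibitor of growth), three compounds sharing one core have been measured, and they differ only in the chain on a nitrogen on an aromatic ring. With an ethyl chain, compound 1 `CCN(Cc1ccc(C(=O)NO)cc1)c1ncc(-c2ccc(C)cc2)s1` gives 1120 nM. With longer chains, compound 2 `Cc1ccc(OCCCN(Cc2ccc(C(=O)NO)cc2)c2ncc(-c3ccc(C)cc3)s2)cc1` gives 12200 nM and compound 3 `CCCCCCN(Cc1ccc(C(=O)NO)cc1)c1ncc(-c2ccc(C)cc2)s1` gives 7420 nM. These last two values sit together, with a 1.6-fold lower number from compound 2 to compound 3 (0.22 log units; within the scatter). Both lie well clear of the lowest number, with a 6.6-fold higher number from compound 1 to compound 3 (0.82 log units; beyond the scatter) and an 11-fold higher number from compound 1 to compound 2 (1.04 log units; beyond the scatter).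

Compound 4 `Cc1ccc(-c2cnc(N(Cc3ccc(C(=O)NO)cc3)C(C)C)s2)cc1` cuts the chain back: isopropyl in place of hexyl on a nitrogen on an aromatic ring, with isopropyl in place of hexyl on that nitrogen. Among these three compounds, the longer chains go with the higher numbers, and none goes against this. None of them has a branched chain, however, so the data cannot say how branching counts. Isopropyl is much closer to the ethyl chain of compound 1 than to hexyl, so most of the rise seen in the step to compound 3 is expected to be undone, though perhaps not all of it. The expected change is a 3.7-fold lower number from compound 3 to compound 4 (0.57 log units; beyond the scatter), a move to a lower number. For compound 4 the estimated value is 2000 nM, with an expected range from 800 nM to 5500 nM.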

Compound 4, concentration for 50% growth inhibition: 2180 nM
Beside the measured number, compound 4's estimate is 1.1-fold (0.04 log units) below it; measured number inside the range.
By their numbers in this assay, from the lowest: compounds 1 and 4 (each within the scatter of the next); then compounds 3 and 2 (each within the scatter of the next).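

In this assay, replacing hexyl with isopropyl on a nitrogen on an aromatic ring gives a 3.4-fold lower number from compound 3 to compound 4 (0.53 log units; beyond the scatter) and replacing 3-(4-methylphenoxy)propyl with isopropyl gives a 5.6-fold lower number from compound 2 to compound 4 (0.75 log units; beyond the scatter), so a chain need not be straight to sit clear of the two long chains. The earlier compounds shown here held no branched chain, and the one extra methyl that separates isopropyl from ethyl gives a 1.9-fold higher number from compound 1 to compound 4 (0.29 log units; within the scatter) and so cannot be told apart from the usual spread of repeat measurements. At this position, branching at the saturated chain carbon bound to that nitrogen therefore shows no effect that can be read in this pair, while the two long chains stay apart from the two short ones; nothing measured here accounts for these differences.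

The compounds shown leave open where between isopropyl and hexyl the numbers begin to rise, which a propyl, butyl or pentyl chain on the same nitrogen would help to locate. They also leave open whether a larger branched group such as tert-butyl, a small ring such as cyclopropyl, or a long chain ending in an amine or a carboxylic acid would follow the same trend.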